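Removing a Methoxy Group from a Nicotinic Receptor Ligand

The source may report more compounds than this note shows. Statements on the series, on what has been measured and on what is new or still open speak of the compounds shown alone.

Of the compounds shown here, three have been measured in an assay (strain Wistar) for binding affinity to Neuronal acetylcholine receptor; alpha4/beta2 (Rattus norvegicus); on this read-out higher numbers stand for weaker inhibition and lower numbers for stronger inhibition. Compound 1 `c1ncc(N2CCCNCC2)cc1C1CC1` gives 5.8 nM, compound 2 `CCOc1cncc(N2C3CCNCC2CC3)c1` gives 3 nM, and compound 3 `COc1cncc(N2CCCNCCC2)c1` gives 1 nM. Compound 3 has the lowest number of the three: compound 2 lies a step above it that goes beyond the scatter, and compound 1 lies further above still. Compound 4 `c1cncc(N2CCCNCCC2)c1` is the unmeasured partner of compound 3; the change is hydrogen in place of methoxy on an aromatic carbon. Going by the values given here, no pair of measured compounds differs by this change alone, so nothing measured fixes the direction. A modest rise in the number, just beyond the scatter, is expected for compound 4, giving a 3.0-fold higher number from compound 3 to compound 4 (0.48 log units; beyond the scatter). Compound 4 is therefore estimated at 3 nM, within a range from 0.8 nM to 12 nM.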

Compound 4, half-maximal inhibitory concentration: 0.9 nM
For compound 4 the middle estimate is 3.3-fold (0.52 log units) above the measured one; measured number inside the range.
By their numbers in this assay, from the lowest: compounds 4 and 3 (each within the scatter of the next); then compounds 2 and 1 (each within the scatter of the next).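

In this assay, putting hydrogen in place of methoxy gives a 1.1-fold lower number from compound 3 to compound 4 (0.05 log units; within the scatter), so at this aromatic carbon, two atoms from the ring nitrogen, the two groups cannot be told apart. On this core, the methoxy group is therefore not needed for a low number, and the bare ring does as well. Nothing available offers an explanation for this result. On these data alone, it remains open whether an amine or a carboxylic acid at this position would also read the same, and whether swapping methoxy for hydrogen behaves alike on other cores.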